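Swapping the five-membered ring on a shared core

The source may report more compounds than this note shows. Statements on the series, on what has been measured and on what is new or still open speak of the compounds shown alone.

Measured compounds:
- compound 1 `c1cnc(-c2ccccc2OCC2=NCCN2)nc1`: 90%
- compound 2 `c1ccc(-c2cnccn2)c(OCC2=NCCN2)c1`: 97%
- compound 3 `c1ccc(-c2ccsc2)c(OCC2=NCCN2)c1`: 98%

These values come from a functional assay with Alpha-1A adrenergic receptor (Homo sapiens) as the target, read by calcium flux; on this read-out higher numbers stand for larger maximal responses and lower numbers for smaller maximal responses. Compound 3 sits close to both others: a number 1 percentage points higher from compound 2 to compound 3 (within the scatter) and a number 8 percentage points higher from compound 1 to compound 3 (within the scatter), so the three numbers are effectively the same. Compound 4 `c1ccc(-c2ncc[nH]2)c(OCC2=NCCN2)c1` is not yet measured. The change from compound 3 is 1H-imidazol-2-yl in place of thiophen-3-yl on an aromatic carbon. Going by the values given here, the steps that bear on this are the other swaps of the ring at the same place, a number 7 percentage points higher from compound 1 to compound 2 (within the scatter) and a number 1 percentage points higher from compound 2 to compound 3 (within the scatter), which changed nothing beyond the scatter. Therefore no step beyond the scatter is expected in this assay either; the estimated step is a number 5 percentage points lower from compound 3 to compound 4 (within the scatter). Compound 4 is thus expected to give about 93%, between 78% and 105%.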

Compound 4, largest response reached (reported as maximum), in percent of the reference or control that the assay uses: 122%
Estimate against measurement, compound 4: 29 percentage points below, outside the stated range (above it).
By their numbers in this assay, from the lowest: compounds 1, 2 and 3 (each within the scatter of the next); then compound 4.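

In this assay, the ring at this position turns out to matter: 1H-imidazol-2-yl gives a number 24 percentage points higher from compound 3 to compound 4 (beyond the scatter) and a number 25 percentage points higher from compound 2 to compound 4 (beyond the scatter) and also a number 32 percentage points higher from compound 1 to compound 4 (beyond the scatter) even though the other three rings lie within the scatter of one another. Compared with thiophen-3-yl, the entering ring adds a hydrogen-bond donor, but a single compound cannot tie that donor to the higher response. No measurement at hand explains the rise.

Still open, on these data alone, is whether a 1-methylimidazol-2-yl ring, which lacks that hydrogen, would keep the higher response. An amine or a carboxylic acid at this place also remains untested among the compounds shown.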